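The compounds below may be only part of what the source reports. "The series", "measured", "known", "first", "only" and "open" are said of these compounds alone.

Of the compounds shown here, three built on a shared core have been measured in an ADME assay on the whole organism for inhibition, with Oryza sativa as the target, with a stated time of 4 days; a higher number here means a weaker inhibitor, a lower number a stronger inhibitor. Compound 1 `CCCN(CC)c1nc(Cl)nc(N[C@@H](C)c2ccccc2)n1` gives 479 nM in this assay. Compound 2 `CC[C@@H](C)Nc1nc(Cl)nc(N[C@H](C)c2ccccc2)n1` gives 8320 nM, and compound 3 `CC[C@@H](C)Nc1nc(Cl)nc(N[C@@H](C)c2ccccc2)n1` gives 9770 nM. Compounds 2 and 3 share every atom and bond; the difference between their cores is this: the two compounds have the same atoms and bonds and differ only in configuration as drawn: 1 of 2 stereo elements differ; a stereocentre at a saturated chain carbon is drawn S in compound 3 and R in compound 2. The step between them, a 1.2-fold higher number from compound 2 to compound 3 (0.07 log units; within the scatter), stays within the usual scatter, in keeping with the fact that compounds 2 and 3 differ only in the configuration as drawn. Within the data shown here, the one change that moves the number sits on the aromatic carbon: ethyl(propyl)amino in place of (sec-butyl)amino on an aromatic carbon. That change gives a 20-fold lower number from compound 3 to compound 1 (1.31 log units; beyond the scatter).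

Compound 4 `CCCN(CC)c1nc(Cl)nc(N[C@H](C)c2ccccc2)n1` has not yet been measured in this assay. It stands to compound 2 as compound 1 stands to compound 3: ethyl(propyl)amino in place of (sec-butyl)amino on an aromatic carbon. The surroundings of the change read the same in both pairs, so it is the same change, made twice among the four compounds shown. The expected step is a 20-fold lower number from compound 2 to compound 4 (1.30 log units; beyond the scatter), which rests on the large 20-fold lower number from compound 3 to compound 1 (1.31 log units; beyond the scatter) and on the fact that a 1.2-fold higher number from compound 2 to compound 3 (0.07 log units; within the scatter) lies within the scatter, so that compound 2 begins from essentially the same number as compound 3. Compound 4 is therefore expected to give 420 nM in this assay, with an expected range from 150 nM to 1200 nM. Whether the measurement lands there remains to be seen.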

Compound 4, half-maximal inhibitory concentration: 24500 nM
The estimate for compound 4 lay 58-fold (1.77 log units) below the measured number; the measured number lies above the stated range.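

On the core of compound 2, the change gives a 2.9-fold higher number from compound 2 to compound 4 (0.47 log units; beyond the scatter), which runs in the opposite direction to the earlier step, so in this assay the effect of putting ethyl(propyl)amino in place of (sec-butyl)amino does not carry from one core to the other: the same change on two cores in this assay, a 20-fold lower number (1.31 log units; beyond the scatter) from compound 3 to compound 1 and a 2.9-fold higher number (0.47 log units; beyond the scatter) from compound 2 to compound 4, 60-fold (1.78 log units) apart, beyond the scatter of two such steps. The two cores differ only at one stereocentre, yet with ethyl(propyl)amino on the aromatic carbon, configuration gives a 51-fold higher number from compound 1 to compound 4 (1.71 log units; beyond the scatter), while with (sec-butyl)amino there it gives only a 1.2-fold higher number from compound 2 to compound 3 (0.07 log units; within the scatter), so the size of a configuration step also depends on the group present: the fact that compounds 1 and 4 differ only in the configuration as drawn. These four compounds show that the change cannot be assumed to transfer between these two cores, but with only two instances they give no general rule for the series and do not show why the steps part.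

As far as these compounds go, it remains open whether a dimethylamino or dipropylamino group on that aromatic carbon would show the same dependence on configuration. From the compounds shown here alone, it is equally open whether a piperidinyl group there, or a methoxy group in place of the chloro group, would keep it.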